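Notes on the carbamate-to-sulfonamide swap at the ring carbon

The source may hold more compounds than are shown below. What is called first, only, known or untested is meant among the compounds shown, and "the series" means these compounds.

Compound 3 `COC(=O)NC1C[C@@H]2CCCC[C@@H]2[C@H]1/C=C/c1ccc(-c2cccc(F)c2)cn1` carries a (methoxycarbonyl)amino group on a saturated ring carbon of the shared core, and in an assay on cell membranes for displacement of a labelled ligand from proteinase-activated receptor 1 (Homo sapiens), read by scintillation counting, with a stated time of 60 min (on this read-out lower numbers stand for stronger inhibition and higher numbers for weaker inhibition), compound 3 gives 980 nM. Among the compounds with values here, that is the highest number among the three measured members. Compound 1 `OC1C[C@@H]2CCCC[C@@H]2[C@H]1/C=C/c1ccc(-c2cccc(F)c2)cn1`, with hydroxy at the same carbon, gives 220 nM in this assay, and compound 2 `CN(C)C(=S)OC1C[C@@H]2CCCC[C@@H]2[C@H]1/C=C/c1ccc(-c2cccc(F)c2)cn1`, the dimethylthiocarbamate ester of that hydroxy, gives 120 nM. The step of a 4.5-fold higher number from compound 1 to compound 3 (0.65 log units; beyond the scatter) and the step of an 8.2-fold higher number from compound 2 to compound 3 (0.91 log units; beyond the scatter) both go against compound 3, which is the weakest of the three; the step of a 1.8-fold lower number from compound 1 to compound 2 (0.26 log units; within the scatter) is small.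

Compound 4 `CN(C1C[C@@H]2CCCC[C@@H]2[C@H]1/C=C/c1ccc(-c2cccc(F)c2)cn1)S(C)(=O)=O` takes the change (methyl(methylsulfonyl)amino in place of (methoxycarbonyl)amino on a saturated ring carbon). Within the data shown here, no measured step involves a sulfonamide or a methylated nitrogen, so none of the three steps bears on it directly. The two steps into compound 3 only show that the carbamate sits at the weak end of what has been measured, which leaves the direction from compound 3 open and the uncertainty wide. For compound 4 the expected step is a 1.1-fold lower number from compound 3 to compound 4 (0.04 log units; within the scatter), no more than the scatter. The estimate for compound 4 in this assay is 900 nM, with a range from 250 nM to 3500 nM.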

Compound 4, half-maximal inhibitory concentration: 1.3 nM
Estimate against measurement, compound 4: 690-fold (2.84 log units) above; measured number below the stated range.
By their numbers in this assay, from the lowest: compound 4; then compounds 2 and 1 (each within the scatter of the next); then compound 3.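

In this assay, within the data shown here, this saturated ring carbon turns out to be far more sensitive to its substituent than the earlier compounds suggested: the carbamate-to-sulfonamide swap gives a 750-fold lower number from compound 3 to compound 4 (2.88 log units; beyond the scatter) and makes compound 4 the strongest of the four. The gain is not merely a recovery from a weak carbamate, since methyl(methylsulfonyl)amino also clearly outperforms the hydroxy group, with a 170-fold lower number from compound 1 to compound 4 (2.23 log units; beyond the scatter) and the dimethylthiocarbamate ester, with a 92-fold lower number from compound 2 to compound 4 (1.97 log units; beyond the scatter) in the same series. The entering group has 0 hydrogen-bond donors where the leaving group has 1, but nothing shown connects that count or any other feature to the size of the gain.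

The swap from compound 3 to compound 4 changes both the carbonyl-to-sulfonyl part and the substituent on the nitrogen, so the contribution of each remains unresolved; methylsulfonylamino without the nitrogen methyl and the nitrogen-methylated form of the carbamate would separate them. Also open, on these data alone, is how far the group tolerates change, for example with ethylsulfonyl in place of methylsulfonyl, a longer chain on the nitrogen, or a plain amine at this carbon.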